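Furan-2-yl for iodo in a series at the assay limit

This account rests on a few compounds, and the source may have more. Where it says the series, first, only, none or still open, it means among the compounds named here.

Compound 1 `COc1ncnc2c1c(I)cn2[C@@H]1O[C@H](CO)[C@@H](O)[C@H]1O` is read in a functional assay on CEM-DNR-bulk cells (Homo sapiens), read by MTT assay, with a stated time of 72 h; on this read-out lower numbers stand for stronger inhibition and higher numbers for weaker inhibition. In this assay compound 1 gives only a limit, > 20000 nM. Compound 2 `Nc1nc(N)c2c(-c3ccoc3)cn([C@@H]3O[C@H](CO)[C@@H](O)[C@H]3O)c2n1` likewise gives only a limit in this assay, > 20000 nM. Compound 3 `CNc1ncnc2c1c(-c1ccccc1)cn2[C@@H]1O[C@H](CO)[C@@H](O)[C@H]1O` also gives only a limit in this assay, > 20000 nM. Compound 1 therefore stands where every value shown stands: the limit of > 20000 nM in this assay, at which 3 of the 3 values shown sit. No step between measured compounds is shown, so no measured size of change is at hand. Compound 4 `COc1ncnc2c1c(-c1ccco1)cn2[C@@H]1O[C@H](CO)[C@@H](O)[C@H]1O` differs from compound 1 by furan-2-yl in place of iodo on an aromatic carbon. For compound 4 the expected step that the limit leaves unreadable from compound 1 to compound 4 is none beyond the scatter, most likely ending again at a limit. Compound 4 is thus estimated at 30000 nM, with a range of 8000 nM to 120000 nM.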

Compound 4, half-maximal inhibitory concentration: 160 nM
Beside the measured number, compound 4's estimate is 190-fold (2.27 log units) above it; measured number outside the range, below it.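

In this assay, the aromatic carbon two ring bonds from the ring nitrogen turns out to tolerate a change that moves the read-out off the limit: furan-2-yl in place of iodo gives an at least 120-fold lower number from compound 1 to compound 4 (2.09 log units; beyond the scatter). The value of compound 1 is a limit, so this step has a bound and not an exact size. Compound 4 alone leaves that limit: the limit of > 20000 nM in this assay, at which 3 of the 4 values shown sit.

Still open, as far as these compounds go, is whether the step is particular to furan-2-yl. A thiophen-2-yl or an amine on this same carbon of the core of compound 4 would address that.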